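This account rests on a few compounds, and the source may have more. Where it says the series, first, only, none or still open, it means among the compounds named here.

Measured compounds:
- compound 1, `O=C(CCC1=CCN(Cc2ccc(F)cc2)C1=O)NO`: 6060 nM in a functional assay on NUGC-3 cells (Homo sapiens) for inhibition, read by sulforhodamine B assay; a lower number here means a stronger inhibitor of growth, a higher number a weaker inhibitor of growth
- compound 2, `O=C(CCC1=CCN(Cc2ccc(Br)cc2)C1=O)NO`: "not determined" (no result reported) in this assay

The two measured compounds share one core and differ only in the group carried on the benzyl ring. In this assay compound 1 gives 6060 nM, a modest level of growth inhibition. Compound 2, which carries a bromo group where compound 1 carries a fluoro group, has no single number in this assay: the result was not determined, so nothing can be said about how the two measured compounds compare with each other.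

Compound 3, `O=C(CCC1=CCN(Cc2ccc(Br)cc2F)C1=O)NO`, is built from compound 2 by one change: fluoro in place of hydrogen on an aromatic carbon. The added fluoro sits ortho to a large group and meta to the bromo group that compound 2 already carries. Among the compounds with values here, since compound 2 has no value in this assay, no step can be computed, and a single added fluorine on an aromatic ring would not be expected to move the number beyond the usual scatter in either direction. Taking compound 1 as the only anchor, compound 3 is expected to give about 5000 nM in this assay, with a likely range from 1500 nM to 16000 nM.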

Compound 3, concentration for 50% growth inhibition: 4280 nM
Estimate against measurement, compound 3: 1.2-fold (0.07 log units) above; the range from low to high includes it.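

Within the data shown here, compound 3 gives 4280 nM but compound 2 has no single number in this assay so no step between compound 2 and compound 3 can be read. From the compounds shown here alone, whether fluoro in place of hydrogen on the aromatic carbon changes growth inhibition remains open. No supporting measurement here bears on this result.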